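Ethyl to propyl at the aromatic nitrogen

A few compounds are considered here, and "the series" means these few. Any claim that something is new, unique, unknown or untested is made for them only; others in the source may bear on it.

Compound 1 `CC[n+]1ccn(COCC(C)(C)[N+](=O)[O-])c1/C=N/O` and compound 2 `CC[n+]1ccn(COCCS(C)(=O)=O)c1/C=N/O` share one core. In a physicochemical assay for lipophilicity (a lower number here means a more polar compound, a higher number a more lipophilic compound), compound 1 gives -1.77. For compound 2 this assay returns only a limit, < -3. The step of a number at least 1.23 log units lower from compound 1 to compound 2 (beyond the scatter) is accordingly known only as a bound, set by the limit of < -3 in this assay, at which 1 of the 2 values shown sits. Compound 3 `CCC[n+]1ccn(COCCS(C)(=O)=O)c1/C=N/O` carries methyl in place of hydrogen on a saturated chain carbon, two bonds along the chain from an aromatic nitrogen. No measured step concerns this change; the one shown step sits elsewhere and cannot size it. A small rise in this assay, or none beyond the scatter, is expected, so the expected step of a number at least 0.20 log units higher from compound 2 to compound 3 (that floor lies within the scatter) is modest. Compound 3 is estimated at -2.8, range -3.5 to -2.2, and may again return only a limit.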

Compound 3, distribution coefficient: < -3
Compound 3 was reported as a limit (the forecaster's own chance of this, stated with the estimate: 65%); middle value at least 0.20 log units away from the limit.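

Compound 2 and compound 3 are both reported only as limits, so no step between them can be read: the limit of < -3 in this assay, at which 2 of the 3 values shown sit.

The compounds shown leave open what size of step, if any, methyl in place of hydrogen produces in this assay.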